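The source may hold more compounds than are shown below. What is called first, only, known or untested is meant among the compounds shown, and "the series" means these compounds.

Compound 1 `Oc1ccc(NC(=S)Nc2ccc3[nH]ccc3c2)cc1` and compound 2 `S=C(Nc1ccc(Oc2ccccc2)cc1)Nc1ccc2[nH]ccc2c1` share one core, and both have been tested in an ADME assay on isolated protein for inhibition of peroxidase (Raphanus sativus), read by fluorescence and Amplex Red, tested at 5 uM; a lower number here means a stronger effect, a higher number a weaker effect of the compound at the concentration tested. There compound 1 gives 41.5%, the lowest of the two numbers, and compound 2 gives 73.1%. Among the compounds with values here, the only measured step, a number 31.6 percentage points higher from compound 1 to compound 2 (beyond the scatter), comes from a phenyl in place of hydrogen on an oxygen on an aromatic ring. Compound 3 `Oc1ccc(NC(=S)Nc2ccc3[nH]ccc3c2)cc1Cl` has not been measured yet. It differs from compound 1 by chloro in place of hydrogen on an aromatic carbon. Within the data shown here, no measured step involves a chloro group, so the step from compound 1 to compound 2 offers no direct guide; it shows only that this assay can move far with a single change. With nothing pointing in either direction, a step within the scatter is the plainest expectation, and compound 3 is estimated at 42%, with a range from 25% to 60%. That estimate means a step of a number 0.5 percentage points higher from compound 1 to compound 3 (within the scatter) is expected.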

Compound 3, a percentage reported as activity, at one concentration (the size of the read-out at that concentration, not a potency): 39.9%
Beside the measured number, compound 3's estimate is 2.1 percentage points above it, and the stated range covers the measured number.
By their numbers in this assay, from the lowest: compounds 3 and 1 (each within the scatter of the next); then compound 2.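

Chloro in place of hydrogen on an aromatic carbon, ortho to a hydroxy group, gives a number 1.6 percentage points lower from compound 1 to compound 3 (within the scatter) in this assay, so compound 3 and compound 1 read alike at this position. The earlier pair showed only a large move, a number 31.6 percentage points higher from compound 1 to compound 2 (beyond the scatter), for a change on the oxygen; this result shows that a single change on the same ring does not always shift the number beyond the usual spread of repeated measurements. No measurement is available that would explain why this change leaves the number where it is.

Going by these compounds, whether bromo, a methyl group, a methoxy group or an amine on the same carbon would also read like compound 1 stays open. So does whether chloro at this place would give the same result in compound 2, which carries a phenyl on the oxygen.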